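Changing the Saturated Ring on the Thiocarbonyl Carbon

The source may hold more compounds than are shown below. What is called first, only, known or untested is meant among the compounds shown, and "the series" means these compounds.

Three compounds share one core and differ only in the saturated ring attached to the thiocarbonyl carbon. In a functional assay on MCF7 cells (Homo sapiens) for cytotoxicity, read by MTT assay, with a stated time of 72 h, tested at 30 uM (on this read-out lower numbers stand for less inhibition of growth and higher numbers for more inhibition of growth at the one concentration tested), compound 1 `Cc1cccc(/C(N)=N/NC(=S)N2CCSCC2)n1` gives 38.6%, compound 2 `Cc1cccc(/C(N)=N/NC(=S)N2CCOCC2)n1` gives 57.8%, and compound 3 `Cc1cccc(/C(N)=N/NC(=S)N2CCCCC2)n1` gives 43%. Compound 3 thus stands second highest of the three: its number sits close to that of compound 1, the step being a number 4.4 percentage points higher from compound 1 to compound 3 (within the scatter), while the step of a number 14.8 percentage points lower from compound 2 to compound 3 (beyond the scatter) sets it clearly apart from compound 2.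

Compound 4 `Cc1cccc(/C(N)=N/NC(=S)N2CCCC2)n1` has not yet been tested. It differs from compound 3 in one place: pyrrolidin-1-yl in place of piperidin-1-yl on a thiocarbonyl carbon. Within the data shown here, none of the measured steps changes the ring size in this way; the two steps that end at compound 3 each swap one six-membered ring for another, and they ranged from a change too small to trust, a number 4.4 percentage points higher from compound 1 to compound 3 (within the scatter), to a modest one, a number 14.8 percentage points lower from compound 2 to compound 3 (beyond the scatter). Nothing among these numbers suggests that a five-membered ring in place of a six-membered one should move the read-out more than those swaps did, so a step within the scatter is expected in this assay, in either direction. Compound 4 is therefore expected to give about 43% in this assay, between 28% and 58%. The expected step is no change at the digits printed from compound 3 to compound 4 (within the scatter).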

Compound 4, percent growth inhibition at one concentration: 40.1%
Estimate against measurement, compound 4: 2.9 percentage points above; low and high end bracket the measured number.
By their numbers in this assay, from the lowest: compounds 1, 4 and 3 (each within the scatter of the next); then compound 2.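

Shrinking the ring on the thiocarbonyl carbon from piperidin-1-yl to pyrrolidin-1-yl is the first change of ring size in this series, and in this assay it comes to (a number 2.9 percentage points lower from compound 3 to compound 4 (within the scatter)), so this pair shows no readable effect of ring size. The pyrrolidin-1-yl compound also cannot be told apart from the thiomorpholin-4-yl compound (a number 1.5 percentage points higher from compound 1 to compound 4 (within the scatter)), but it is clearly separated from the morpholin-4-yl compound (a number 17.7 percentage points lower from compound 2 to compound 4 (beyond the scatter)). Compounds 1, 3 and 4 therefore form one group whose values lie within the scatter of each other, and compound 2 alone stands apart, with steps beyond the scatter to all three others.

On these data alone, it remains open whether other groups on the thiocarbonyl carbon, such as piperazin-1-yl, the larger azepan-1-yl ring or an open-chain diethylamino group, would fall with compounds 1, 3 and 4 or reach the level of compound 2. No separate measurement is available that could explain why compound 2 stands apart from the other three.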